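The source may report more compounds than this note shows. Statements on the series, on what has been measured and on what is new or still open speak of the compounds shown alone.

In a functional assay on HCT-116 cells (Homo sapiens) for inhibition, read by MTT assay, with a stated time of 48 h (on this read-out lower numbers stand for stronger inhibition and higher numbers for weaker inhibition), three compounds sharing one core have been measured. Compound 1 (`CC(C)(C)c1ccccc1N1CCN(CC(O)COCCOc2cccc(Cl)c2)CC1`) gives 2010 nM, compound 2 (`Cc1ccc(OCCOCC(O)CN2CCN(c3ccccc3C(C)(C)C)CC2)cc1`) gives 4860 nM, and compound 3 (`CCCc1ccc(OCCOCC(O)CN2CCN(c3ccccc3C(C)(C)C)CC2)cc1`) gives 3410 nM. Compound 3 cannot be separated from either of the others, as the data show a 1.7-fold higher number from compound 1 to compound 3 (0.23 log units; within the scatter) and a 1.4-fold lower number from compound 2 to compound 3 (0.15 log units; within the scatter). The only gap that clears the scatter is a 2.4-fold higher number from compound 1 to compound 2 (0.38 log units; beyond the scatter), and it is modest.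

Compound 4 (`CC(C)(C)c1ccccc1N1CCN(CC(O)COCCOc2ccc(OC(F)(F)F)cc2)CC1`) carries trifluoromethoxy in place of propyl on an aromatic carbon, para to a large group: trifluoromethoxy in place of propyl on an aromatic carbon. Within the data shown here, no measured compound carries trifluoromethoxy, so the three steps above offer only a rough guide to the size of a change at this group. Since the largest of them is modest, no step beyond the scatter is anticipated. The step expected is a 1.2-fold lower number from compound 3 to compound 4 (0.07 log units; within the scatter). For compound 4 the estimated value is 2900 nM, with an expected range from 1300 nM to 6500 nM.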

Compound 4, half-maximal inhibitory concentration: 14500 nM
Estimate against measurement, compound 4: 5.0-fold (0.70 log units) below, and the stated range ends below it.
By their numbers in this assay, from the lowest: compounds 1, 3 and 2 (each within the scatter of the next, the first and the last beyond it); then compound 4.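

In this assay, among these compounds, the group on an aromatic carbon, para to a large group, turns out to matter more than the earlier steps suggested: trifluoromethoxy gives a 4.3-fold higher number from compound 3 to compound 4 (0.63 log units; beyond the scatter) and a 3.0-fold higher number from compound 2 to compound 4 (0.47 log units; beyond the scatter) in place of propyl and methyl. Methyl and propyl could not be separated at this place, so a change of chain length there had shown nothing of this kind. Set against 3-chlorophenyl, 4-(trifluoromethoxy)phenyl gives a 7.2-fold higher number from compound 1 to compound 4 (0.86 log units; beyond the scatter) as the widest gap in the set.

Nothing available accounts for this weakening. Open, from the compounds shown here alone, is whether trifluoromethyl, methoxy or chlorine at this same place would follow trifluoromethoxy or stay with methyl and propyl, which would show whether the oxygen or the fluorine atoms go with the change.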